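The compounds below may be only part of what the source reports. "The series", "measured", "known", "first", "only" and "open" are said of these compounds alone.

Compound 1, `COC(=O)[C@@]1(C)CCC=C2[C@@H]1CC[C@@H](C)[C@]2(C)Cc1c[nH]c2ccc(F)cc12`: 3700 nM
Compound 2, `COC(=O)[C@@]1(C)CCC=C2[C@@H]1CC[C@@H](C)[C@]2(C)Cc1c[nH]c2ccc(OC)cc12`: 1200 nM
Compound 3, `COC(=O)[C@@]1(C)CCC=C2[C@@H]1CC[C@@H](C)[C@]2(C)Cc1c(C)[nH]c2ccc(F)cc12`: 11000 nM

These three compounds were tested in a functional assay on HeLa cells (Homo sapiens) for inhibition, read by sulforhodamine B assay, with a stated time of 48 h; on this read-out higher numbers stand for weaker inhibition of growth and lower numbers for stronger inhibition of growth. They share one core, and differ only in small groups attached to it. Going from compound 1 to compound 2 the change is methoxy in place of fluoro on an aromatic carbon, and it gave a 3.1-fold lower number from compound 1 to compound 2 (0.49 log units; beyond the scatter). Going from compound 1 to compound 3 the change is methyl in place of hydrogen on an aromatic carbon, and it gave a 3.0-fold higher number from compound 1 to compound 3 (0.47 log units; beyond the scatter). Compound 3 thus gives the highest number of the three in this assay, and compound 2 the lowest.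

Compound 4, `COC(=O)[C@@]1(C)CCC=C2[C@@H]1CC[C@@H](C)[C@]2(C)Cc1c(C)[nH]c2ccc(OC)cc12`, has not yet been measured. It differs from compound 3 by methoxy in place of fluoro on an aromatic carbon. This is the same change as that from compound 1 to compound 2: the group that leaves, the group that enters and the place are described in the same words for both pairs. The two cores on which the change is made differ only in the methyl group that sets compound 3 apart from compound 1, as described above.

The expectation for compound 4 rests on the step of a 3.1-fold lower number from compound 1 to compound 2 (0.49 log units; beyond the scatter), which the same change produced on the core of compound 1. On that basis compound 4 is expected to give 3600 nM, with a likely range from 1600 nM to 8000 nM. That would correspond to an estimated step of a 3.1-fold lower number from compound 3 to compound 4 (0.49 log units; beyond the scatter).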

Compound 4, concentration for 50% growth inhibition: 12000 nM
Compound 4: middle estimate off by 3.3-fold (0.52 log units), on the low side; measured number above the stated range.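

Methoxy in place of fluoro did not carry over from one core to the other in this assay: on the core bearing the extra methyl the change gave a 1.1-fold higher number from compound 3 to compound 4 (0.04 log units; within the scatter), and set beside the earlier step, the result differs: the same change on two cores in this assay, a 3.1-fold lower number (0.49 log units; beyond the scatter) from compound 1 to compound 2 and a 1.1-fold higher number (0.04 log units; within the scatter) from compound 3 to compound 4, 3.4-fold (0.53 log units) apart, beyond the scatter of two such steps

Read the other way, methyl in place of hydrogen gave a 10-fold higher number from compound 2 to compound 4 (1.00 log units; beyond the scatter) on the methoxy core, a larger step than on the fluoro core, so the two changes do not simply add up: the same change on two cores in this assay, a 3.0-fold higher number (0.47 log units; beyond the scatter) from compound 1 to compound 3 and a 10-fold higher number (1.00 log units; beyond the scatter) from compound 2 to compound 4, 3.4-fold (0.53 log units) apart, beyond the scatter of two such steps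

This shows that, in these four compounds, the lower number seen with methoxy appears only on the core without the extra methyl; it does not show why, and four compounds cannot say how the change would behave on any other core.

The compounds shown leave open whether this loss of the methoxy step is tied to methyl itself or would also appear with another group at that place, such as ethyl or chloro. They also leave open whether another group in place of fluoro, such as hydroxy or ethoxy, would give different steps on the two cores, as methoxy does.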